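Swapping the aryl ketone: from difluorophenyl toward methoxyphenyl

This account rests on a few compounds, and the source may have more. Where it says the series, first, only, none or still open, it means among the compounds named here.

Of the compounds shown here, three sharing one core have been tested in a functional assay on MCF7 cells (Homo sapiens) for cytotoxicity, read by MTT assay, with a stated time of 48 h; a lower number here means a stronger inhibitor, a higher number a weaker inhibitor. Compound 1 `COc1cc(C(=O)C2Sc3nnc(-c4cc(OC)c(OC)c(OC)c4)n3NC2c2ccco2)cc(OC)c1OC` carries a 3,4,5-trimethoxyphenyl on the carbonyl carbon; compound 1 gives > 100000 nM, which is a limit of the assay rather than a number. Compound 2 `COc1cc(-c2nnc3n2NC(c2ccco2)C(C(=O)c2cccc4ccccc24)S3)cc(OC)c1OC` carries a naphthalen-1-yl there; compound 2 gives > 100000 nM, again a limit. Among the measured compounds shown here, compound 3 `COc1cc(-c2nnc3n2NC(c2ccco2)C(C(=O)c2ccc(F)c(F)c2)S3)cc(OC)c1OC` carries a 3,4-difluorophenyl, and compound 3 gives 73200 nM, the only actual number among the three. The step that the two limits leave unreadable from compound 1 to compound 2 cannot be read. The steps of an at least 1.3-fold lower number from compound 1 to compound 3 (0.13 log units; that floor lies within the scatter) and an at least 1.3-fold lower number from compound 2 to compound 3 (0.13 log units; that floor lies within the scatter) point toward a lower number, though their floors lie within the scatter, due to the limit of > 100000 nM in this assay, at which 2 of the 3 values shown sit.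

Compound 4 `COc1cccc(C(=O)C2Sc3nnc(-c4cc(OC)c(OC)c(OC)c4)n3NC2c2ccco2)c1` is the next member. The change from compound 3 is 3-methoxyphenyl in place of 3,4-difluorophenyl on a carbonyl carbon. This moves the group back toward the methoxy-bearing phenyl of compound 1, the reverse of the direction of an at least 1.3-fold lower number from compound 1 to compound 3 (0.13 log units; that floor lies within the scatter), so a higher number is expected for compound 4, possibly again only a limit. The estimate for compound 4 in this assay is 110000 nM, between 45000 nM and 300000 nM, and the step of a 1.5-fold higher number from compound 3 to compound 4 (0.18 log units; within the scatter) is expected to go upward.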

Compound 4, half-maximal inhibitory concentration: > 100000 nM
Compound 4: a limit, no number (the forecaster's own chance of this, stated with the estimate: 60%); the middle value is on the limit's open side.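

As far as these compounds go, what compound 4 adds is that a single methoxy group on the ketone's phenyl ring is enough to leave the measurable range: 3-methoxyphenyl in place of 3,4-difluorophenyl on the carbonyl carbon gives an at least 1.3-fold higher number from compound 3 to compound 4 (0.13 log units; that floor lies within the scatter), so the size of this change stays unknown and it may be small or large. Until now, only the heavily substituted 3,4,5-trimethoxyphenyl had stood for the methoxy-bearing groups, and now compound 1 and compound 4 both end in a limit, though compound 2, with naphthalen-1-yl and no methoxy on that ring, does the same. The steps among compound 1, compound 2 and compound 4 cannot be read, and the three cannot be ranked, due to the ceiling they share: the limit of > 100000 nM in this assay, at which 3 of the 4 values shown sit.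

Among the compounds shown here, compound 3 therefore remains the only member with an actual number, and a single number cannot show what this position prefers. Still open, from the compounds shown here alone, is how a plain phenyl would behave at this carbonyl, or a phenyl bearing an amine or a carboxylic acid, and whether any such group would give a value clearly beyond the scatter.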